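This account rests on a few compounds, and the source may have more. Where it says the series, first, only, none or still open, it means among the compounds named here.

Measured so far in an assay on microsomes from brain for inhibition of Fatty-acid amide hydrolase 1 (Rattus norvegicus), read by fluorescence and HPLC, with a stated time of 60 min; on this read-out lower numbers stand for stronger inhibition and higher numbers for weaker inhibition:
compound 1, `CCCCCCCCc1ccc(OCC(=O)Cn2ncc3ccccc32)cc1`: 2300 nM
compound 2, `CCCCCCCCc1ccc(OCC(=O)Cn2cnc3ccccc32)cc1`: 480 nM

Compound 2 holds the lower of the two numbers in this assay; compound 1 sits a step away, a 4.8-fold lower number from compound 1 to compound 2 (0.68 log units; beyond the scatter). That one step is the whole record for the heterocycle on the saturated chain carbon bound to the carbonyl carbon, and it shows that exchanging one bicyclic group for another at this position can move the number beyond the scatter.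

Compound 3, `CCCCCCCCc1ccc(OCC(=O)Cn2ncc3cccnc32)cc1`, is the next member. It differs from compound 2 by a group of 9 heavy atoms (6 carbon, 3 nitrogen; one five-membered aromatic ring with 2 hetero atoms, one six-membered aromatic ring with 1 hetero atom) in place of a group of 9 heavy atoms (7 carbon, 2 nitrogen; one five-membered aromatic ring with 2 hetero atoms, one six-membered aromatic ring of carbon only), on a saturated chain carbon bound to a carbonyl carbon. For the measured compounds named here, no measured step tests this particular exchange: the step from compound 1 to compound 2 swaps the five-membered ring arrangement, whereas here the six-membered ring gains a ring nitrogen and the five-membered ring is reworked as well. The precedent therefore only sets a scale, not a direction.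

Compound 3 is expected to land near compound 2, with a step of a 1.9-fold higher number from compound 2 to compound 3 (0.27 log units; within the scatter), and a wide range around it. The estimate for compound 3 in this assay is 900 nM, between 250 nM and 3500 nM.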

Compound 3, half-maximal inhibitory concentration: 1600 nM
Compound 3: the middle estimate sits 1.8-fold (0.25 log units) below what was measured; measured number inside the range.
By their numbers in this assay, from the lowest: compound 2; then compounds 3 and 1 (each within the scatter of the next).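

In this assay, the group on the saturated chain carbon bound to a carbonyl carbon now has three readings, and 1H-benzimidazol-1-yl remains the one that stands apart: the step (a 3.3-fold higher number from compound 2 to compound 3 (0.52 log units; beyond the scatter)) goes against compound 3 by a margin of the same modest class as the earlier step. Against 1H-indazol-1-yl, the new group with its six-membered aromatic ring with 1 hetero atom shows no difference that can be read (a 1.4-fold lower number from compound 1 to compound 3 (0.16 log units; within the scatter)), so this change to the six-membered ring leaves compound 3 level with compound 1 within the scatter. Nothing at hand bears on the reason for either step.

The compounds shown leave open whether a six-membered aromatic ring with 1 hetero atom would leave the number of compound 2 as unmoved as it leaves that of compound 1. Also open, on these data alone, is how an amine, a carboxylic acid or a single-ring imidazole would read in place of the bicyclic group on the saturated chain carbon bound to a carbonyl carbon.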